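Adding a second hydroxy to compound 2

The source may hold more compounds than are shown below. What is called first, only, known or untested is meant among the compounds shown, and "the series" means these compounds.

Compound 1 (`Cc1cccc(-c2cc3occ(C)c3c(=O)o2)c1`) gives 1.5 uM in a functional assay on SK-BR-3 cells (Homo sapiens) for cytotoxicity, read by sulforhodamine B assay, with a stated time of 72 h (a lower number here means that less compound is needed, a higher number that more compound is needed for the effect), and compound 2 (`Cc1coc2cc(-c3cccc(O)c3)oc(=O)c12`) gives 1.61 uM there, level with compound 1 within the scatter, while compound 3 (`Cc1coc2cc(-c3cccc(F)c3)oc(=O)c12`) gives 20.5 uM and stands clearly higher. Compound 4 (`Cc1coc2cc(-c3ccc(O)c(O)c3)oc(=O)c12`) differs from compound 2 by one change (hydroxy in place of hydrogen on an aromatic carbon), with the new hydroxy ortho to a hydroxy group and para to a large group. Within the data shown here, no measured step replaces a hydrogen, so the evidence is indirect. Exchanging methyl for hydroxy stays within the scatter (a 1.1-fold higher number from compound 1 to compound 2 (0.03 log units; within the scatter)), whereas the fluoro exchanges are large (a 14-fold higher number from compound 1 to compound 3 (1.14 log units; beyond the scatter) and a 13-fold higher number from compound 2 to compound 3 (1.10 log units; beyond the scatter)). No step beyond the scatter is therefore expected in this assay for this hydroxy addition. The estimated step (a 1.1-fold higher number from compound 2 to compound 4 (0.05 log units; within the scatter)) is small. For compound 4 the expected value is 1.8 uM within an estimated range of 0.5 uM to 7 uM in this assay.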

Compound 4, concentration for half-maximal effect: 0.47 uM
Beside the measured number, compound 4's estimate is 3.8-fold (0.58 log units) above it, outside the stated range (below it).
By their numbers in this assay, from the lowest: compound 4; then compounds 1 and 2 (each within the scatter of the next); then compound 3.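

In this assay, hydroxy in place of hydrogen on an aromatic carbon, ortho to a hydroxy group and para to a large group, gives a 3.4-fold lower number from compound 2 to compound 4 (0.53 log units; beyond the scatter) and so lowers the number beyond the scatter. Among the steps shown, this is the only one beyond the scatter that goes downward; the other two, both entering fluoro, raise the number. This position therefore tolerates added substitution in this series, at least for hydroxy.

Going by these compounds, whether an amine or a methoxy at this position would also lower the number remains open. The cause of this step also remains open, with no measured evidence bearing on it.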